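The source may report more compounds than this note shows. Statements on the series, on what has been measured and on what is new or still open speak of the compounds shown alone.

Measured so far in a functional assay on CHO cells for activation of 5-hydroxytryptamine receptor 1D (Homo sapiens), read by GTPgammaS binding; on this read-out higher numbers stand for larger maximal responses and lower numbers for smaller maximal responses:
compound 1 `O=S(=O)(NCC1CCN(CCCc2c[nH]c3ccc(-n4cnnc4)cc23)CC1)c1ccccc1`: 73%
compound 2 `COC[C@H](NC1CCN(CCCc2c[nH]c3ccc(Cn4cncn4)cc23)CC1)c1ccc(F)cc1`: 89%
compound 3 `O[C@@H]1Cc2ccccc2[C@H]1NC1CCN(CCCc2c[nH]c3ccc(-n4cnnc4)cc23)CC1`: 75%

Compound 2 gives the highest of the three numbers, with compound 3 and compound 1 both beyond the scatter below it. For the measured compounds named here, the one step between measured compounds that differ in a single place, a number 2 percentage points higher from compound 1 to compound 3 (within the scatter), changes a group on a saturated ring carbon and lies within the scatter. Compound 4 `OC[C@H](NC1CCN(CCCc2c[nH]c3ccc(Cn4cncn4)cc23)CC1)c1ccccc1` differs from compound 2 on the amine nitrogen: 2-hydroxy-1-phenylethyl in place of 1-(4-fluorophenyl)-2-methoxyethyl on an amine nitrogen. Going by the values given here, no measured step alters this position, so the step has no direct precedent. Among the compounds with values here, with the one available step within the scatter and the other two compounds both lower, compound 4 is expected to give 82% (68% to 95%), an expected change of a number 7 percentage points lower from compound 2 to compound 4 (within the scatter).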

Compound 4, largest response reached (reported as efficacy), in percent of the reference or control that the assay uses: 76%
Compound 4: middle estimate off by 6 percentage points, on the high side; low and high end bracket the measured number.
By their numbers in this assay, from the lowest: compounds 1, 3 and 4 (each within the scatter of the next); then compound 2.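

In this assay, for the compounds shown here, the change on the amine nitrogen gives a number 13 percentage points lower from compound 2 to compound 4 (beyond the scatter), so this position, unlike the saturated ring carbon of the one earlier step, shows a response that moves with the substituent. The change from 1-(4-fluorophenyl)-2-methoxyethyl to 2-hydroxy-1-phenylethyl alters the fluorine and the ether end together, so the step belongs to the pair and not to either part. No measurement shown gives a cause for the step.

Open, from the compounds shown here alone, is which part carries the step: 2-methoxy-1-phenylethyl and 1-(4-fluorophenyl)-2-hydroxyethyl on the same nitrogen would separate the two. An amine or a carboxylic acid at the end of that chain also remains untested in the compounds shown.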